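This account rests on a few compounds, and the source may have more. Where it says the series, first, only, none or still open, it means among the compounds named here.

Three compounds sharing one core were tested in an assay on isolated protein for inhibition of DNA topoisomerase 1 (Homo sapiens), with a stated time of 30 min, tested at 100 uM; a lower number here means a weaker effect, a higher number a stronger effect of the compound at the concentration tested. Compound 1 `Cc1ccc2nc(-c3cccc(OC(F)(F)F)c3)[nH]c(=O)c2c1` gives 98.6%, the highest of the three numbers. Compound 2 `Cc1ccc2c(=O)[nH]c(-c3ccccc3F)nc2c1` gives 81.2%, a number beyond the scatter below that of compound 1, and compound 3 `Cc1ccc2nc(-c3ccccc3C(F)(F)F)[nH]c(=O)c2c1` gives 72%, the furthest from compound 1, also beyond the scatter. No two of these differ in only one place, so no single step can be read from them. Compound 4 `COc1cccc(-c2nc3ccc(C)cc3c(=O)[nH]2)c1` has not yet been measured in this assay. It differs from compound 1 in one place: methyl in place of trifluoromethyl on an oxygen on an aromatic ring. Among the measured compounds shown here, with no comparable step among the measured compounds, the change is expected to cost some inhibition, as a step of a number 13.6 percentage points lower from compound 1 to compound 4 (beyond the scatter). Compound 4 is therefore estimated at 85%, between 60% and 99%.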

Compound 4, a percentage reported as inhibition, at one concentration (the size of the read-out at that concentration, not a potency): 71.8%
Estimate against measurement, compound 4: 13.2 percentage points above; the range from low to high includes it.
By their numbers in this assay, from the lowest: compounds 4, 3 and 2 (each within the scatter of the next); then compound 1.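

In this assay, among the compounds shown here, the change from trifluoromethoxy to methoxy gives the first step that can be read, a number 26.8 percentage points lower from compound 1 to compound 4 (beyond the scatter). At this place, on an oxygen on an aromatic ring, methyl therefore does not retain the inhibition seen with trifluoromethyl on the shared core. Nothing available explains the size of this step. From the compounds shown here alone, whether the loss comes from removing the fluorine atoms alone stays open, as does how an ethyl group on that oxygen, or an amine in place of the whole trifluoromethoxy, would read.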